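Swapping an aromatic ring for cyclohexyl on the chain

A few compounds are considered here, and "the series" means these few. Any claim that something is new, unique, unknown or untested is made for them only; others in the source may bear on it.

Measured so far in a functional assay on HeLa cells (Homo sapiens) for cytotoxicity, read by WST assay, with a stated time of 48 h; on this read-out higher numbers stand for weaker inhibition and lower numbers for stronger inhibition:
- compound 1 `COc1cccc(/C=C/C[C@H]2C[C@@H]([C@@H](O)c3ccccc3)CO[C@@H]2c2ccccc2)c1`: 10900 nM
- compound 2 `COc1ccc(/C=C/C[C@H]2C[C@@H]([C@@H](O)c3ccccc3)CO[C@@H]2c2ccccc2)cc1`: 8300 nM
- compound 3 `Cc1ccc(/C=C/C[C@H]2C[C@@H]([C@@H](O)c3ccccc3)CO[C@@H]2c2ccccc2)cc1C`: 10000 nM

All three compounds share one core and differ only in the ring at the end of the chain. Compound 3 stands level with the other two, since the step of a 1.1-fold lower number from compound 1 to compound 3 (0.04 log units; within the scatter) and the step of a 1.2-fold higher number from compound 2 to compound 3 (0.08 log units; within the scatter) both lie within the scatter of repeated measurements.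

Compound 4 `O[C@@H](c1ccccc1)[C@H]1CO[C@H](c2ccccc2)[C@@H](C/C=C/C2CCCCC2)C1` keeps the shared core and has cyclohexyl in place of 3,4-dimethylphenyl on a double-bonded chain carbon bound to a double-bonded chain carbon.

The two steps above bear on this change, as does the step of a 1.3-fold lower number from compound 1 to compound 2 (0.12 log units; within the scatter), which is also within the scatter. All three exchange one aromatic ring for another at this same place. None of them introduces a non-aromatic ring, so they are only a loose guide to the new step. On that evidence, no step beyond the scatter is expected in this assay, and neither direction is favoured. The expected result is no change at the digits printed from compound 3 to compound 4 (within the scatter). For compound 4 the estimate is 10000 nM, with an expected range from 4500 nM to 22000 nM.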

Compound 4, half-maximal inhibitory concentration: 6440 nM
Compound 4: middle estimate off by 1.6-fold (0.19 log units), on the high side; the measured number falls inside the stated range.
By their numbers in this assay, from the lowest: compounds 4, 2, 3 and 1 (each within the scatter of the next).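

For the compounds shown here, this is the first non-aromatic ring at this place, on a double-bonded chain carbon bound to a double-bonded chain carbon, and in this assay cyclohexyl in place of 3,4-dimethylphenyl gives a 1.6-fold lower number from compound 3 to compound 4 (0.19 log units; within the scatter), while in place of 4-methoxyphenyl it gives a 1.3-fold lower number from compound 2 to compound 4 (0.11 log units; within the scatter) and in place of 3-methoxyphenyl it gives a 1.7-fold lower number from compound 1 to compound 4 (0.23 log units; within the scatter). Among these four compounds, then, the end of the chain need not carry an aromatic ring for the number to stay level: the earlier compounds only compared aromatic rings with one another, whereas here a saturated ring of carbon only sits level with all three. No measurement is available that would explain this result.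

Going by these compounds, all four compounds end in a six-membered carbon ring, so it remains open whether any group at this place can move the number beyond the scatter. An amine or a carboxylic acid on the ring would test this, as would an open butyl chain in place of the ring or a much smaller ring such as cyclopropyl.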